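The source may hold more compounds than are shown below. What is called first, only, known or untested is meant among the compounds shown, and "the series" means these compounds.

Working notes on the series. Compound 1 `Cc1ccc(-n2cc(NC(=O)c3cccc(NS(=O)(=O)c4ccc(Cl)cc4)c3)cn2)cc1` is the reference: in a functional assay on HepG2 cells (Homo sapiens) for inhibition, read by MTT assay, with a stated time of 48 h (on this read-out higher numbers stand for weaker inhibition and lower numbers for stronger inhibition), compound 1 gives 2440 nM. Compound 2 `COc1ccc(-n2cc(NC(=O)c3cccc(NS(=O)(=O)c4ccc(Cl)cc4)c3)cn2)cc1` differs by methoxy in place of methyl on an aromatic carbon and in this assay compound 2 gives 15200 nM, the step being a 6.2-fold higher number from compound 1 to compound 2 (0.79 log units; beyond the scatter). Compound 3 `Cc1ccc(-n2cc(NC(=O)c3ccc(NS(=O)(=O)c4ccccc4)cc3)cn2)cc1` carries a different core; the difference between the two cores is not broken down here. In this assay compound 3 gives 18100 nM, which lies within the scatter of compound 2 and well beyond it from compound 1.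

Compound 4 `COc1ccc(-n2cc(NC(=O)c3ccc(NS(=O)(=O)c4ccccc4)cc3)cn2)cc1` awaits measurement and differs from compound 3 by methoxy in place of methyl on an aromatic carbon, the same change as from compound 1 to compound 2. The same direction is expected, but compound 3 already sits at the weak end, so a smaller step is estimated, around a 2.2-fold higher number from compound 3 to compound 4 (0.34 log units; beyond the scatter), because of the earlier 6.2-fold higher number from compound 1 to compound 2 (0.79 log units; beyond the scatter). For compound 4 the expected value in this assay is 40000 nM, between 14000 nM and 110000 nM.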

Compound 4, half-maximal inhibitory concentration: 57300 nM
Compound 4: the middle estimate sits 1.4-fold (0.16 log units) below what was measured; measured number inside the range.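

In this assay, methoxy in place of methyl again goes with weaker inhibition, with a 3.2-fold higher number from compound 3 to compound 4 (0.50 log units; beyond the scatter). Both steps run in the same direction, and their sizes cannot be told apart: the same change on two cores in this assay, a 6.2-fold higher number (0.79 log units; beyond the scatter) from compound 1 to compound 2 and a 3.2-fold higher number (0.50 log units; beyond the scatter) from compound 3 to compound 4, 2.0-fold (0.29 log units) apart, within the scatter of two such steps. This shows that the change carries over between these two cores, but two pairs do not show that it carries to other cores, nor what sets the size of the step.

The compounds shown leave open how an amine or a carboxylic acid in place of methyl on the 4-methylphenyl group would read in this assay. They also leave open which of the differences between the two cores matter, since none is varied alone here.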